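Solubility notes on the aryl swap in this series

A few compounds are considered here, and "the series" means these few. Any claim that something is new, unique, unknown or untested is made for them only; others in the source may bear on it.

Measured compounds:
- Compound 1 `Cc1cc(NCc2ccccn2)n2ncc(-c3ccc(C#N)cc3)c2n1`: in a physicochemical assay for solubility, read by HPLC, using the shake flask method, measured as kinetic solubility, with a stated time of 2 h, at pH 7.4 (a higher number here means a more soluble compound, a lower number a less soluble compound), compound 1 gives < 5000 nM, a limit of the assay and not a number (the limit of < 5000 nM in this assay, at which 1 of the 3 values shown sits).
- Compound 2 `Cc1cc(NCc2ccccn2)n2ncc(-c3ccsc3)c2n1`: compound 2 gives 9000 nM.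
- Compound 3 `Cc1cc(NCc2ccccn2)n2ncc(-c3cccc(N)c3)c2n1`: compound 3 gives 160000 nM.

Compound 3 stands highest of the two numbers shown; compound 2 is its nearest neighbour, with the step of an 18-fold higher number from compound 2 to compound 3 (1.25 log units; beyond the scatter), while the step of an at least 32-fold higher number from compound 1 to compound 3 (1.50 log units; beyond the scatter) starts from a limit. The step of an at least 1.8-fold higher number from compound 1 to compound 2 (0.25 log units; that floor lies within the scatter) also starts from a limit and stays within the scatter.

Compound 4 `Cc1cc(NCc2ccccn2)n2ncc(-c3ccc(F)cc3C)c2n1` differs from compound 3 in one place: 4-fluoro-2-methylphenyl in place of 3-aminophenyl on an aromatic carbon. Among the compounds with values here, the steps that bear on this change are those that brought the 3-aminophenyl in, an at least 32-fold higher number from compound 1 to compound 3 (1.50 log units; beyond the scatter) and an 18-fold higher number from compound 2 to compound 3 (1.25 log units; beyond the scatter), both large. Taking the 3-aminophenyl out again and putting in 4-fluoro-2-methylphenyl, a group with no hydrogen-bond donor or acceptor, is expected to reverse a step of that order in this assay, downward. Compound 4 is therefore estimated at 4000 nM, within 800 nM to 15000 nM, an expected step of a 40-fold lower number from compound 3 to compound 4 (1.60 log units; beyond the scatter); a reading at the limit of the assay is a real possibility.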

Compound 4, solubility: 42300 nM
Compound 4: the middle estimate sits 11-fold (1.02 log units) below what was measured, and the stated range ends below it.
By their numbers in this assay, from the lowest: compound 2; then compound 4; then compound 3. At a limit, below all of these: compound 1.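

In this assay, taking out 3-aminophenyl does not return the series to the bottom of its range: a 3.8-fold lower number from compound 3 to compound 4 (0.58 log units; beyond the scatter) is a smaller drop than the steps that brought the 3-aminophenyl in, and a 4.7-fold higher number from compound 2 to compound 4 (0.67 log units; beyond the scatter) places the new group clearly above thiophen-3-yl. A number well above that of compound 2 at this aromatic carbon therefore does not require a hydrogen-bond donor or acceptor on the entering group, since 4-fluoro-2-methylphenyl counts 0 hydrogen-bond donors and 0 hydrogen-bond acceptors, although 3-aminophenyl in compound 3 still stands higher. The comparison with the nitrile-bearing group, an at least 8.4-fold higher number from compound 1 to compound 4 (0.92 log units; beyond the scatter), gives only a floor for the size of that step, and compound 1 is a limit of the assay and not a number: the limit of < 5000 nM in this assay, at which 1 of the 4 values shown sits.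

The compounds shown do not separate the fluorine from the methyl in 4-fluoro-2-methylphenyl, and an unsubstituted phenyl would be needed as the common reference for both that group and 3-aminophenyl. From the compounds shown here alone, it also stays open whether a more strongly ionisable group at this carbon, such as a carboxylic acid or a dimethylamino group, would go beyond compound 3 in this assay.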